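Ester chain variation on the shared core

A few compounds are considered here, and "the series" means these few. Any claim that something is new, unique, unknown or untested is made for them only; others in the source may bear on it.

Compound 3 `CCCCN(CCCC)Cc1cn(CC(O)COC(=O)C2CCCCC2)nn1` is the cyclohexylcarbonyl ester of the series; in an assay on nucleic acid for inhibition of Nucleic Acid, read by fluorescence, tested at 100 uM (on this read-out lower numbers stand for less inhibition and higher numbers for more inhibition at the one concentration tested (going by the name of the read-out)), compound 3 gives 12%. Among the three measured compounds compound 3 stands second highest. Within the data shown here, compound 1 `CCCCN(CCCC)Cc1cn(CC(O)COC(=O)NCc2ccccc2)nn1` gives 42%, so that a number 30 percentage points lower from compound 1 to compound 3 (beyond the scatter) is the one step on the carbonyl carbon that lies beyond the scatter. Compound 2 `CCCCN(CCCC)Cc1cn(CC(O)COCc2ccccc2)nn1` gives 6%; the step of a number 6 percentage points higher from compound 2 to compound 3 (within the scatter) is within the scatter, so the benzyl ether and the cyclohexyl ester read alike in this assay.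

Compound 4 `CCCCCCCC(=O)OCC(O)Cn1cc(CN(CCCC)CCCC)nn1` carries heptyl in place of cyclohexyl on a carbonyl carbon. Among the measured compounds shown here, no measured step exchanges a ring for an open chain, so the bearing steps are indirect: a number 6 percentage points higher from compound 2 to compound 3 (within the scatter) shows that changing the group on the oxygen between a benzyl and a cyclohexylcarbonyl did not move this assay, while a number 30 percentage points lower from compound 1 to compound 3 (beyond the scatter) shows that the large change came with benzylamino, which compound 4 also lacks. The step of a number 2 percentage points higher from compound 3 to compound 4 (within the scatter) is therefore expected to stay within the scatter. Compound 4 is estimated at 14%, with a range from 3% to 28%.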

Compound 4, a percentage reported as inhibition, at one concentration (the size of the read-out at that concentration, not a potency): 71%
The estimate for compound 4 lay 57 percentage points below the measured number, outside the stated range (above it).
By their numbers in this assay, from the lowest: compounds 2 and 3 (each within the scatter of the next); then compound 1; then compound 4.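

Among these compounds, on the carbonyl carbon the identity of the group matters far more than the earlier compounds suggested: a number 59 percentage points higher from compound 3 to compound 4 (beyond the scatter) in this assay with an open heptyl chain in place of the cyclohexyl ring, a swap of nearly the same heavy-atom count. A benzylamino group is also not needed for a high number at this place, since the series shows a number 29 percentage points higher from compound 1 to compound 4 (beyond the scatter) on going to heptyl, and a number 65 percentage points higher from compound 2 to compound 4 (beyond the scatter) with heptylcarbonyl in place of benzyl on the oxygen. Nothing available accounts for this gain.

With a single open chain, the compounds cannot separate the effect of chain length from that of losing the ring. A shorter butyl chain, a longer dodecyl chain or a branched chain on the carbonyl carbon would begin to settle this.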